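Fluoro for hydroxy on the benzyl ring of compound 2

The compounds below may be only part of what the source reports. "The series", "measured", "known", "first", "only" and "open" are said of these compounds alone.

Compound 1 `Oc1cccc(CNc2cc(Br)cc3[nH]ncc23)c1` gives 55% in an assay for inhibition of Tryptophan 2,3-dioxygenase (Homo sapiens), with a stated time of 1 h, tested at 10 uM; on this read-out lower numbers stand for less inhibition and higher numbers for more inhibition at the one concentration tested (going by the name of the read-out). Compound 2 `Oc1ccc(CNc2cc(Br)cc3[nH]ncc23)cc1O`, which carries a second hydroxy group, is reported in this assay only as "not active" (no number reported), so compound 2 stands on no single number and its distance from compound 1 cannot be sized. Compound 3 `Oc1ccc(CNc2cc(Br)cc3[nH]ncc23)cc1F` differs from compound 2 by fluoro in place of hydroxy on an aromatic carbon. Within the data shown here, with no measured step between these two, the direction in this assay is expected to run upward from compound 2, back toward the single-hydroxy compound 1, though the size is unknown. Compound 3 is estimated at 30%, between 5% and 60%, with a fair chance of again being reported only as inactive.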

Compound 3, a percentage reported as inhibition, at one concentration (the size of the read-out at that concentration, not a potency): 26%
Compound 3: middle estimate off by 4 percentage points, on the high side; measured number inside the range.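

Among these compounds, no step from compound 2 to compound 3 can be read, as compound 2 has no number. The compounds shown leave open how large the change from hydroxy to fluoro is. No measurement shown bears on a cause.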